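Limit-bound compounds and an untested rearrangement

The source may report more compounds than this note shows. Statements on the series, on what has been measured and on what is new or still open speak of the compounds shown alone.

Compound 1 `COc1cc(NC(C)CCCN2C(=O)CN(C(=O)[C@H](C)N)C2(C)C)c2ncccc2c1`: 46300 nM
Compound 2 `COc1cc(NC(C)CCCNC(=O)CN2C(=O)[C@H](C)NC2(C)C)c2ncccc2c1`: > 100000 nM (a limit of the assay)
Compound 3 `COc1cc(NC(C)CCCNC(=O)CN2C(=O)[C@H](C)NC23CCCCC3)c2ncccc2c1`: > 100000 nM (a limit of the assay)

All three compounds were tested in a functional assay on HT-29 cells (Homo sapiens) for antiproliferative activity, read by sulforhodamine B assay, with a stated time of 48 h; a higher number here means a weaker inhibitor, a lower number a stronger inhibitor. Going by the values given here, compound 1 is the only one with a measured number, 46300 nM. Compound 2 has no number, only a limit of the assay, > 100000 nM. Compound 3 also gives only a limit, > 100000 nM. The series therefore offers little to work from: the limit of > 100000 nM in this assay, at which 2 of the 3 values shown sit.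

Compound 4 `COc1cc(NC(C)CCCNC(=O)C2CCCN2C(=O)[C@@H](C)N)c2ncccc2c1` has the same atoms as compound 2, joined differently: 1-((1-aminoethyl)carbonyl)pyrrolidin-2-yl in place of (2,2,4-trimethyl-5-oxoimidazolidin-1-yl)methyl on a carbonyl carbon. In words, 1-((1-aminoethyl)carbonyl)pyrrolidin-2-yl stands in place of (2,2,4-trimethyl-5-oxoimidazolidin-1-yl)methyl on a carbonyl carbon.

Among the compounds with values here, no measured pair isolates this change, so only a modest gain in strength is expected in this assay, given that compound 1 reaches 46300 nM. The estimated change is an at least 1.2-fold lower number from compound 2 to compound 4 (0.09 log units; that floor lies within the scatter). Compound 4 is expected at 80000 nM, with an estimated range of 30000 nM to 200000 nM.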

Compound 4, half-maximal inhibitory concentration: > 100000 nM
Compound 4 ended at the assay's limit; the forecaster's own chance of this, stated with the estimate: 55%; at least 1.2-fold (0.09 log units) between middle value and limit.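

Compound 2 and compound 4 both rest on a limit in this assay, and no step can be read between them, because both sit at that limit: the limit of > 100000 nM in this assay, at which 3 of the 4 values shown sit.

The compounds shown leave open whether 1-((1-aminoethyl)carbonyl)pyrrolidin-2-yl or (2,2,4-trimethyl-5-oxoimidazolidin-1-yl)methyl on a carbonyl carbon gives the stronger inhibitor.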